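The compounds below may be only part of what the source reports. "The series", "measured", "known", "first", "only" and "open" are said of these compounds alone.

Measured so far:
Compound 1, `Cc1ccc(/C=C2\S/C(=N\c3csc(-c4ccc(Cl)cc4)c3)NC2=O)cc1`: 900 nM
Compound 2, `O=C1N/C(=N/c2csc(-c3ccc(Cl)cc3)c2)S/C1=C\c1ccc2ccccc2c1`: 1200 nM

Both numbers come from a functional assay on MCF7 cells (Homo sapiens) for cytotoxicity, read by MTT assay, with a stated time of 72 h; a higher number here means a weaker inhibitor, a lower number a stronger inhibitor. Within the data shown here, only two compounds have been measured, and their numbers sit close together: the one step between them, a 1.3-fold higher number from compound 1 to compound 2 (0.12 log units; within the scatter), shows no difference beyond the scatter of repeated measurement, so compound 2 cannot be set apart from compound 1 on these numbers.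

Compound 3, `O=C1N/C(=N/c2csc(-c3ccc(Cl)cc3)c2)S/C1=C\c1ccc(F)cc1`, has not yet been measured in this assay. It differs from compound 2 in one place: 4-fluorophenyl in place of naphthalen-2-yl on a double-bonded chain carbon bound to a double-bonded ring carbon. Among the measured compounds shown here, the only measured step that bears on this change is the earlier swap at the same double-bonded chain carbon, a 1.3-fold higher number from compound 1 to compound 2 (0.12 log units; within the scatter), in which a naphthalen-2-yl replaced a 4-methylphenyl and the number stayed essentially where it was. Since 4-fluorophenyl, like 4-methylphenyl, is a single six-membered aromatic ring of carbon only, the same kind of outcome is expected here. For compound 3 the expected step in this assay is therefore a 1.2-fold lower number from compound 2 to compound 3 (0.08 log units; within the scatter), a change no larger than the scatter. Compound 3 is thus estimated at about 1000 nM, within a range from 450 nM to 2500 nM.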

Compound 3, half-maximal inhibitory concentration: > 50000 nM
Compound 3: a limit, no number; the forecaster's own chance of this, stated with the estimate: 5%; middle value at least 50-fold (1.69 log units) from the limit.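

In this assay compound 3 stands at a limit of the assay and not at a number: the limit of > 50000 nM in this assay, at which 1 of the 3 values shown sits. Among these compounds, the place on the double-bonded chain carbon bound to a double-bonded ring carbon looked tolerant while only naphthalen-2-yl and 4-methylphenyl had been compared, but 4-fluorophenyl gives an at least 41-fold higher number from compound 2 to compound 3 (1.61 log units; beyond the scatter) and the single change of fluoro in place of methyl on an aromatic carbon gives an at least 55-fold higher number from compound 1 to compound 3 (1.74 log units; beyond the scatter) as well. The count of aromatic rings does not sort these compounds, since compound 1 and compound 3 each carry one six-membered aromatic ring of carbon only at this place and still lie far apart, so the group on that ring counts here.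

The compounds shown leave open whether another group on that aromatic carbon, such as chloro, methoxy or an amine, would behave like the methyl of compound 1 or like the fluoro of compound 3. A plain phenyl, with only hydrogen on that carbon, is also absent from them, so they cannot tell whether fluoro takes the activity away or methyl supplies it.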